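This account rests on a few compounds, and the source may have more. Where it says the series, first, only, none or still open, it means among the compounds named here.

Compound 3 `O=C(Nn1c(-c2cccc([N+](=O)[O-])c2)nc2c(-c3ccc(Cl)cc3)n[nH]c2c1=O)c1ccccc1` is the starting point of this step and, in a functional assay on SK-OV-3 cells (Homo sapiens) for cytotoxicity, read by sulforhodamine B assay, with a stated time of 2 days, tested at 100 uM (a lower number here means less inhibition, a higher number more inhibition at the concentration tested (going by the name of the read-out)), compound 3 gives 86.8%, the highest of the two numbers reported here. Compound 1 `O=C(Nn1c(-c2cccc([N+](=O)[O-])c2)nc2c(-c3ccc(F)cc3)n[nH]c2c1=O)c1cccnc1`, which differs from it in several places, gives 19.3% in this assay, a gap well beyond the usual scatter. For compound 2 `O=C(Nn1c(-c2cccc([N+](=O)[O-])c2)nc2c(-c3cccc(Cl)c3)n[nH]c2c1=O)c1ccccc1` the result in this assay is "not determined" (no result reported), so no number was reported for it. Compound 4 `O=C(Nn1c(-c2cccc([N+](=O)[O-])c2)nc2c(-c3ccc(F)cc3)n[nH]c2c1=O)c1ccccc1` is reached from compound 3 by one change: fluoro in place of chloro on an aromatic carbon. Going by the values given here, no measured pair shows this change on its own, so its size is uncertain; the step expected here, a number 31.8 percentage points lower from compound 3 to compound 4 (beyond the scatter), is a moderate loss that goes beyond the scatter. Compound 4 is therefore estimated at 55%, within a range from 15% to 88%.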

Compound 4, a percentage reported as inhibition, at one concentration (the size of the read-out at that concentration, not a potency): 77.7%
Compound 4: the middle estimate sits 22.7 percentage points below what was measured; the range from low to high includes it.
By their numbers in this assay, from the lowest: compound 1; then compounds 4 and 3 (each within the scatter of the next).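

In this assay, 4-chlorophenyl to 4-fluorophenyl gives a number 9.1 percentage points lower from compound 3 to compound 4 (within the scatter) and so does not separate these two halogens at this position. Phenyl in place of pyridin-3-yl on the carbonyl carbon gives a number 58.4 percentage points higher from compound 1 to compound 4 (beyond the scatter) in the same compound series, which shows that the low number of compound 1 goes with this ring and not with the fluoro group. Still open, from the compounds shown here alone, is whether a methoxy group or an amine on the same aromatic carbon would keep the inhibition. Nothing measured here explains either step.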